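The compounds below may be only part of what the source reports. "The series", "measured", "known", "first", "only" and "open" are said of these compounds alone.

compound 1 `CC1=C(c2nc(-c3ccc(C#N)cc3)cs2)C(c2ccc(F)nc2)NC(=O)N1`: 49.4%
compound 2 `CC1=C(c2nc(-c3ccc(C#N)cc3)cs2)C(c2ccc(O)cc2)NC(=O)N1`: 100%

Within the data shown here, in an ADME assay on microsomes from liver (Rattus norvegicus) for metabolic stability, read by LC-MS, using NADPH, with stated times of 5 min and 60 min, tested at 4 uM (on this read-out higher numbers stand for a more stable compound and lower numbers for a less stable compound), compound 2 holds the higher of the two numbers at 100%, and compound 1 is the only neighbour. Next in line is compound 3 `COc1ccc(C2NC(=O)NC(C)=C2c2nc(-c3ccc(C#N)cc3)cs2)cc1`, which differs from compound 2 by methyl in place of hydrogen on an oxygen on an aromatic ring: hydroxy to methoxy, or 4-hydroxyphenyl to 4-methoxyphenyl.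

Among the measured compounds shown here, one measured step bears on this change, and only indirectly. It is a number 50.6 percentage points higher from compound 1 to compound 2 (beyond the scatter), a large step beyond the scatter, with 4-hydroxyphenyl in place of 6-fluoropyridin-3-yl on a saturated ring carbon. For the measured compounds named here, that step touches the same substituent on the shared core, but no methoxy compound has been measured, and no measured pair shows what methyl in place of hydrogen on that oxygen does. With so little to go on, a fall in this assay is expected, though a smaller one than the measured step, and the uncertainty is wide.

The expected change is a number 30 percentage points lower from compound 2 to compound 3 (beyond the scatter), which would lie beyond the scatter. Compound 3 is estimated at 70%, with an expected range of 45% to 92%.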

Compound 3, percent of the compound remaining: 63.2%
Estimate against measurement, compound 3: 6.8 percentage points above, and the stated range covers the measured number.
By their numbers in this assay, from the lowest: compound 1; then compound 3; then compound 2.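

In this assay, among these compounds, methyl in place of hydrogen on an oxygen on an aromatic ring gives a number 36.8 percentage points lower from compound 2 to compound 3 (beyond the scatter), the first direct reading at this oxygen, and it shows that the free hydroxy of compound 2 cannot be capped without a large loss on this read-out. At the same time, the 4-methoxyphenyl group still leaves a number 13.8 percentage points higher from compound 1 to compound 3 (beyond the scatter), so only part of the rise seen with 4-hydroxyphenyl survives in compound 3, which sits between the other two compounds with both of its steps beyond the scatter. No measured information accounts for either step.

The compounds shown leave open whether an ethoxy group or a longer chain on that oxygen would lower the number further than methoxy, and whether an amine or a carboxylic acid in place of the hydroxy would keep the number near that of compound 2 at 100%. From the compounds shown here alone, it also remains open whether a fluoro or chloro substituent added to the 4-methoxyphenyl ring would change the reading of compound 3.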